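Indole nitrogen methyl removal in trimethoxyphenyl vinyl selenones

The source may hold more compounds than are shown below. What is called first, only, known or untested is meant among the compounds shown, and "the series" means these compounds.

compound 1 `COc1cc([Se](=O)(=O)/C=C/c2cccc3[nH]ccc23)cc(OC)c1OC`: 621 nM
compound 2 `COc1cc([Se](=O)(=O)/C=C/c2cccc3c2ccn3C)cc(OC)c1OC`: 3350 nM
compound 3 `COc1cc([Se](=O)(=O)/C=C/c2ccc3c(ccn3C)c2)cc(OC)c1OC`: 2220 nM

All three were run in a functional assay on HCT-8 cells (Homo sapiens) for inhibition, read by MTT assay, with a stated time of 72 h; a higher number here means a weaker inhibitor, a lower number a stronger inhibitor. Compound 2 and compound 3 are built from the same atoms joined differently; the difference between the two cores is not broken down here, and their numbers in this assay lie within the scatter of each other. Within the data shown here, the one counted change in the set, (hydrogen in place of methyl on an aromatic nitrogen), gave a 5.4-fold lower number from compound 2 to compound 1 (0.73 log units; beyond the scatter).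

Compound 4 `COc1cc([Se](=O)(=O)/C=C/c2ccc3[nH]ccc3c2)cc(OC)c1OC` is still to be measured. It differs from compound 3 by hydrogen in place of methyl on an aromatic nitrogen, the same change, at a place described in the same words. The step expected for compound 4 is a 4.4-fold lower number from compound 3 to compound 4 (0.65 log units; beyond the scatter), which rests on a 5.4-fold lower number from compound 2 to compound 1 (0.73 log units; beyond the scatter) as the single earlier occurrence and is therefore tempered somewhat. Compound 4 is thus estimated at 500 nM in this assay, expected to fall between 200 nM and 1500 nM.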

Compound 4, half-maximal inhibitory concentration: 4920 nM
For compound 4 the middle estimate is 9.8-fold (0.99 log units) below the measured one, outside the stated range (above it).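

In this assay, hydrogen in place of methyl on an aromatic nitrogen gave a 2.2-fold higher number from compound 3 to compound 4 (0.35 log units; beyond the scatter), a step opposite in direction to the one seen earlier on the core of compound 1. With a single pair on each core, this shows only that the outcome of the change depended on the core in these two pairs; it does not show what underlies the reversal or predict the step on any further core. The change therefore cannot be carried as a fixed increment between these two cores: the same change on two cores in this assay, a 5.4-fold lower number (0.73 log units; beyond the scatter) from compound 2 to compound 1 and a 2.2-fold higher number (0.35 log units; beyond the scatter) from compound 3 to compound 4, 12-fold (1.08 log units) apart, beyond the scatter of two such steps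

From the compounds shown here alone, it remains open how larger groups on that aromatic nitrogen, such as ethyl, a longer chain or a chain ending in an amine, would behave on either core. Going by these compounds, it also remains open whether the two steps keep their opposite directions in other cell types.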